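Compound 3: a new group on the carbonyl carbon

The source may hold more compounds than are shown below. What is called first, only, known or untested is meant among the compounds shown, and "the series" means these compounds.

Of the compounds shown here, two on one shared core have been measured so far. In a physicochemical assay for solubility, read by HPLC, in phosphate buffer, measured as kinetic solubility, at pH 7.4 (on this read-out lower numbers stand for lower solubility and higher numbers for higher solubility), compound 1 `NS(=O)(=O)c1ccc(-c2cc(C(=O)N3CCCC3)nn2-c2ccc(Cl)cc2)cc1` gives 57900 nM, and compound 2 `CN(C(=O)c1cc(-c2ccc(S(N)(=O)=O)cc2)n(-c2ccc(Cl)cc2)n1)C1CC(F)(F)C1` gives 30900 nM. Compound 2 therefore stands level with compound 1, within the scatter. Compound 3 `NS(=O)(=O)c1ccc(-c2cc(C(=O)NC3CC3)nn2-c2ccc(Cl)cc2)cc1` has not yet been measured. It differs from compound 2 at one place: cyclopropylamino in place of (3,3-difluorocyclobutyl)(methyl)amino on a carbonyl carbon. Cyclopropylamino stands in place of (3,3-difluorocyclobutyl)(methyl)amino on a carbonyl carbon. For the measured compounds named here, only one measured step bears on this change, since it also swaps the group on a carbonyl carbon: a 1.9-fold lower number from compound 1 to compound 2 (0.27 log units; within the scatter). That single step gives no reason to expect a large move, though no measured compound carries the entering group, so the expectation stays loose. The estimated step is a 1.0-fold lower number from compound 2 to compound 3 (0.01 log units; within the scatter), expected to stay within the scatter. For compound 3 the estimated value in this assay is 30000 nM, with an expected range of 10000 nM to 75000 nM.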

Compound 3, solubility: 72600 nM
Estimate against measurement, compound 3: 2.4-fold (0.38 log units) below; measured number inside the range.
By their numbers in this assay, from the lowest: compounds 2, 1 and 3 (each within the scatter of the next, the first and the last beyond it).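

In this assay, this carbonyl carbon now shows a step beyond the scatter: cyclopropylamino in place of (3,3-difluorocyclobutyl)(methyl)amino gives a 2.3-fold higher number from compound 2 to compound 3 (0.37 log units; beyond the scatter), a modest move. Cyclopropylamino in place of pyrrolidin-1-yl gives a 1.3-fold higher number from compound 1 to compound 3 (0.10 log units; within the scatter), so compound 1 stands level with compound 3 as well as with compound 2, and only the two outer compounds are told apart. Nothing shown here gives a cause for the step.

That step changes the ring, the fluorine atoms, the methyl on nitrogen and the hydrogen-bond donor count together, and the compounds shown do not separate these changes. From the compounds shown here alone, it remains open how (3,3-difluorocyclobutyl)amino, without the methyl, or an open-chain amine such as dimethylamino on this carbonyl carbon would read in this assay.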